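The source may report more compounds than this note shows. Statements on the series, on what has been measured and on what is new or still open speak of the compounds shown alone.

The measured compounds:
compound 1, `CC(=O)OC[C@H]1O[C@H](OC[C@@H](Cn2cc(CN(c3nc(-c4cccc(C)c4)no3)C3CCCCC3)nn2)OC(C)=O)C=C[C@@H]1OC(C)=O`, 39.2 ug/mL
compound 2, `CC(=O)OC[C@H]1O[C@H](OC[C@@H](Cn2cc(CN(c3nc(-c4ccc(Br)cc4)no3)C3CCCCC3)nn2)OC(C)=O)C=C[C@@H]1OC(C)=O`, 47.6 ug/mL
compound 3, `COc1ccc(-c2noc(N(Cc3cn(C[C@H](CO[C@@H]4C=C[C@H](OC(C)=O)[C@@H](COC(C)=O)O4)OC(C)=O)nn3)C3CCCCC3)n2)cc1`, 141 ug/mL

In an ADME assay on HepG2 cells (Homo sapiens) for cytotoxicity, read by MTT assay, with a stated time of 48 h (a lower number here means that less compound is tolerated, a higher number that more compound is tolerated), compound 3 stands highest of the three numbers. Its lead over compound 2 is shown by a 3.0-fold higher number from compound 2 to compound 3 (0.47 log units; beyond the scatter), and its lead over compound 1 by a 3.6-fold higher number from compound 1 to compound 3 (0.56 log units; beyond the scatter). Between compound 1 and compound 2 the difference is a 1.2-fold higher number from compound 1 to compound 2 (0.08 log units; within the scatter), so those two cannot be ordered.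

Compound 4, `CC(=O)OC[C@H]1O[C@H](OC[C@@H](Cn2cc(CN(c3nc(-c4ccc(C(F)(F)F)cc4)no3)C3CCCCC3)nn2)OC(C)=O)C=C[C@@H]1OC(C)=O`, differs from compound 3 by trifluoromethyl in place of methoxy on an aromatic carbon. For the measured compounds named here, the steps that bear on this are the two that introduced the methoxy group, from compound 2 and from compound 1 to compound 3, both modest and beyond the scatter, both raising the number. Taking the methoxy away again is therefore expected to bring the number back down toward compounds 1 and 2. Going by the values given here, no measured step involves a trifluoromethyl group, so the size of the drop is uncertain. Compound 4 is expected to give 55 ug/mL in this assay, with a range from 25 ug/mL to 130 ug/mL. This corresponds to an expected step of a 2.6-fold lower number from compound 3 to compound 4 (0.41 log units; beyond the scatter).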

Compound 4, half-maximal cytotoxic concentration: 81.4 ug/mL
Beside the measured number, compound 4's estimate is 1.5-fold (0.17 log units) below it; the measured number falls inside the stated range.
By their numbers in this assay, from the lowest: compounds 1, 2, 4 and 3 (each within the scatter of the next, the first and the last beyond it).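

With trifluoromethyl on this aromatic carbon, para to a large group, the clear lead of methoxy over bromo no longer extends to every replacement: in this assay, the change from methoxy stays within the scatter (a 1.7-fold lower number from compound 3 to compound 4 (0.24 log units; within the scatter)), so compound 3 and compound 4 cannot be ordered. The change from bromo also stays within the scatter (a 1.7-fold higher number from compound 2 to compound 4 (0.23 log units; within the scatter)), which places compound 4 in reach of both compound 2 and compound 3, although those two lie beyond the scatter of each other. Only the replacement of 3-methylphenyl by 4-(trifluoromethyl)phenyl passes beyond the scatter, and modestly (a 2.1-fold higher number from compound 1 to compound 4 (0.32 log units; beyond the scatter)).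

No measurement available gives a reason for these differences. The compounds shown leave open whether an amine or a carboxylic acid at this place would give a number outside those seen so far.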